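The source may report more compounds than this note shows. Statements on the series, on what has been measured and on what is new or still open speak of the compounds shown alone.

Measured compounds:
compound 1, `O=C(c1ccc(Cl)c(C(F)(F)F)c1)N1CCC(n2cncc2-c2ccc(OS(=O)(=O)c3ccccc3)cc2)CC1`, 702 nM
compound 2, `O=C(c1ccc(Cl)c(C(F)(F)F)c1)N1CCC(n2cncc2-c2ccc(OS(=O)(=O)c3cccs3)cc2)CC1`, 238 nM
compound 3, `Nc1cccc(S(=O)(=O)Oc2ccc(-c3cncn3C3CCN(C(=O)c4ccc(Cl)c(C(F)(F)F)c4)CC3)cc2)c1`, 565 nM

In an assay on HEK293 cells for antagonist activity at P2X purinoceptor 7 (Homo sapiens), read by fluorescence, with a stated time of 2 h (a lower number here means a stronger inhibitor, a higher number a weaker inhibitor), compound 1 carries the highest of the three numbers shown. Its nearest neighbour is compound 3, and that gap lies within the scatter (a 1.2-fold lower number from compound 1 to compound 3 (0.09 log units; within the scatter)). The furthest is compound 2, a modest step beyond the scatter (a 2.9-fold lower number from compound 1 to compound 2 (0.47 log units; beyond the scatter)). The pair compound 2 and compound 3 is also separated by a modest step (a 2.4-fold higher number from compound 2 to compound 3 (0.38 log units; beyond the scatter)).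

Compound 4, `O=C(c1ccc(Cl)c(C(F)(F)F)c1)N1CCC(n2cncc2-c2ccc(OS(=O)(=O)c3cccc(Br)c3)cc2)CC1`, differs from compound 1 by bromo in place of hydrogen on an aromatic carbon of the six-membered aromatic ring of carbon only, meta to a large group, so that the phenylsulfonyl arm becomes (3-bromophenyl)sulfonyl.

Among the compounds with values here, two measured steps bear on this. Within the data shown here, the nearest precedent is a substituent placed on the same ring, compound 1 to compound 3, which stayed within the scatter (a 1.2-fold lower number from compound 1 to compound 3 (0.09 log units; within the scatter)). Replacing the whole ring by thiophen-2-yl, compound 1 to compound 2, gave a modest lowering (a 2.9-fold lower number from compound 1 to compound 2 (0.47 log units; beyond the scatter)). A single halogen on the retained phenyl is therefore expected to shift the number little, if anything slightly downward; the expected step is a 1.4-fold lower number from compound 1 to compound 4 (0.15 log units; within the scatter). Compound 4 is estimated at 500 nM, with a range from 200 nM to 1300 nM.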

Compound 4, half-maximal inhibitory concentration: 896 nM
Compound 4: middle estimate off by 1.8-fold (0.25 log units), on the low side; low and high end bracket the measured number.
By their numbers in this assay, from the lowest: compound 2; then compounds 3, 1 and 4 (each within the scatter of the next).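

In this assay, bromo in place of hydrogen on the phenyl ring of the phenylsulfonyl arm, meta to a large group, stays within the scatter (a 1.3-fold higher number from compound 1 to compound 4 (0.11 log units; within the scatter)), and bromo in place of amino at that same carbon also stays within the scatter (a 1.6-fold higher number from compound 3 to compound 4 (0.20 log units; within the scatter)), so compounds 1, 3 and 4 cannot be told apart here and neither substituent on this ring gives a readable change. Within the data shown here, the 3-bromophenyl arm also sits clearly apart from the thiophen-2-yl arm (a 3.8-fold higher number from compound 2 to compound 4 (0.58 log units; beyond the scatter)), leaving compound 2 as the one compound of the four separated beyond the scatter from all the others, with the replacement of the ring, rather than substitution on it, as the only change so far that moves the number. Nothing available here explains why these two substituents leave the number unmoved.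

Still open, as far as these compounds go, is whether this insensitivity extends to a carboxylic acid or a methoxy group at this carbon, or to bromo elsewhere on the ring. From the compounds shown here alone, it is equally open whether the gain of compound 2 belongs to thiophen-2-yl alone or would carry over to another five-membered ring such as furan-2-yl.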